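This account rests on a few compounds, and the source may have more. Where it says the series, first, only, none or still open, it means among the compounds named here.

Measured in a functional assay on brain (Rattus norvegicus, strain Wistar) for inhibition; on this read-out higher numbers stand for weaker inhibition and lower numbers for stronger inhibition:
- compound 1 `COc1ccc(-c2c(C)[nH]c(=O)n2C2CCCCC2)cc1`: 20400 nM
- compound 2 `CCCCCCc1ccc(-c2c(C)[nH]c(=O)n2C2CCCCC2)cc1`: 13700 nM
- compound 3 `CCCCCCOc1ccc(-c2c(C)[nH]c(=O)n2C2CCCCC2)cc1`: 8500 nM

Compound 3 stands at 8500 nM. It is separated from the other two compounds by a 1.6-fold lower number from compound 2 to compound 3 (0.21 log units; within the scatter) and by a 2.4-fold lower number from compound 1 to compound 3 (0.38 log units; beyond the scatter).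

The next compound is compound 4 `Cc1[nH]c(=O)n(C2CCCCC2)c1-c1ccc(-c2ccccc2)cc1`, which differs from compound 3 as follows: phenyl in place of hexyloxy on an aromatic carbon. In words, this is phenyl in place of hexyloxy on an aromatic carbon. For the measured compounds named here, no measured compound carries phenyl at this place, so the data offer no direct precedent.

The closest guides are the other exchanges of groups at this carbon. These are a 1.5-fold lower number from compound 1 to compound 2 (0.17 log units; within the scatter), a 1.6-fold lower number from compound 2 to compound 3 (0.21 log units; within the scatter) and a 2.4-fold lower number from compound 1 to compound 3 (0.38 log units; beyond the scatter), and only the last lies beyond the scatter, and modestly. Across these three compounds the group at this carbon has moved the number little.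

A step within the scatter is therefore expected in this assay. A slight lean towards a higher number is expected, as compound 1, with the short methoxy group, gives 20400 nM. The estimated change is a 1.3-fold higher number from compound 3 to compound 4 (0.11 log units; within the scatter). For compound 4 the expected value is 11000 nM, with an estimated range from 4500 nM to 26000 nM.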

Compound 4, half-maximal inhibitory concentration: 10900 nM
Compound 4: the middle estimate sits 1.0-fold (0.00 log units) above what was measured; the range from low to high includes it.
By their numbers in this assay, from the lowest: compounds 3, 4, 2 and 1 (each within the scatter of the next, the first and the last beyond it).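

In this assay, a ring at this position, on an aromatic carbon para to a large group, proves no different from the open chains: a 1.3-fold higher number from compound 3 to compound 4 (0.11 log units; within the scatter), a 1.3-fold lower number from compound 2 to compound 4 (0.10 log units; within the scatter), and even against the short methoxy group there is a 1.9-fold lower number from compound 1 to compound 4 (0.27 log units; within the scatter). The earlier compounds had shown only chains joined directly or through oxygen, whereas this result adds an aromatic ring of carbon only, with no hydrogen-bond acceptor in place of the one in hexyloxy, and still yields no step beyond the scatter. The evidence at hand offers nothing that accounts for how little these exchanges move the number.

Whether this carbon is as undemanding towards an amine, a carboxylic acid or a hydroxyl group stays open, since every group shown here consists of carbon, with at most a single oxygen, and carries no net charge. Going by these compounds, it is also open whether a substituted phenyl or a longer chain at this carbon could bring the number clearly below those of all four compounds, or whether other parts of the shared core matter more.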